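The compounds below may be only part of what the source reports. "The series", "measured", "known", "first", "only" and "open" are said of these compounds alone.

Compound 1 `O=C(O)c1cc(-n2c(-c3ccccc3)cc3c2CCCC3)ccc1O`, >= 60%; compound 2 `O=C(O)c1ccc(-n2c(-c3ccccc3)cc3c2CCCC3)cc1O`, 0%; compound 3 `CC(=O)Oc1ccc(-n2c(-c3ccccc3)cc3c2CCCC3)cc1C(=O)O`, 50%.

In a functional assay on the whole organism (strain Wistar) for inhibition, with Rattus norvegicus as the target, read by paw edema, with stated times of 30 min and 3 h, at a dose of 200 mg/kg by the oral route (on this read-out higher numbers stand for more inhibition at the one dose given (going by the name of the read-out) and lower numbers for less inhibition), compound 1 gives >= 60%, which is a limit of the assay and not a number (the limit of >= 60% in this assay, at which 1 of the 3 values shown sits). Compound 3 gives 50%, so that a number at least 10 percentage points lower from compound 1 to compound 3 (that floor lies within the scatter). Compound 2 gives 0%. Compound 4 `O=C(O)c1cc(-n2c(-c3ccccc3)cc3c2CCCC3)ccc1Cl` differs from compound 1 in one place: chloro in place of hydroxy on an aromatic carbon. Going by the values given here, the only measured step touching this oxygen is the one from compound 1 to compound 3; it stays within the scatter but points downward, and compound 4 keeps no oxygen there at all. A downward step is therefore expected for compound 4, a number at least 20 percentage points lower from compound 1 to compound 4 (beyond the scatter). The estimate for compound 4 is 40%, with a range from 15% to 65%.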

Compound 4, a percentage reported as inhibition, in the whole organism at one dose (the size of the read-out at that dose, not a potency): 40%
Beside the measured number, compound 4's estimate shows no gap at the digits printed; the range from low to high includes it.
By their numbers in this assay, from the lowest: compound 2; then compounds 4 and 3 (each within the scatter of the next). At a limit, above all of these: compound 1.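

Going by these compounds alone, on this aromatic carbon, chloro in place of hydroxy gives the first step beyond the scatter in this assay: a number at least 20 percentage points lower from compound 1 to compound 4 (beyond the scatter). Chloro and acetoxy are not separated here, with a number 10 percentage points lower from compound 3 to compound 4 (within the scatter), although only acetoxy keeps an oxygen on this carbon. For compound 1, >= 60% is a limit of the assay and not a number.

The compounds shown leave open how a methoxy group or an amine on this same aromatic carbon would read, and whether a fluoro or bromo group would match chloro.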